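Swapping Chloro for Fluoro: Expected Half-Life of Compound 4

This account rests on a few compounds, and the source may have more. Where it says the series, first, only, none or still open, it means among the compounds named here.

Three compounds sharing one core have been run in an ADME assay on the whole organism (Macaca fascicularis) for metabolic stability, read by LC-MS, using cassette dosing, at a dose of 1 mg/kg by the oral route; on this read-out higher numbers stand for a longer-lived compound and lower numbers for a shorter-lived compound. Compound 1 `C[C@H](c1ccc(-c2cc(F)ccc2-c2nc(=O)o[nH]2)cc1)N(CC1CC1)c1nc2c(C(=O)O)cccc2o1` gives 4.1 h. Compound 2 `CCCCN(c1nc2c(C(=O)O)cccc2o1)[C@H](C)c1ccc(-c2cc(Cl)ccc2-c2nc(=O)o[nH]2)cc1` gives 2 h. Compound 3 `CCCCN(c1nc2c(C(=O)O)cccc2o1)[C@H](C)c1ccc(-c2ccccc2-c2nnn[nH]2)cc1` gives 3.7 h. Among these three, compound 2 has the lowest number; its gap to compound 3 lies within the usual scatter of such measurements, while its gap to compound 1 lies just beyond it, so only compound 1 can be called longer-lived than compound 2 with any confidence.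

The unmeasured compound 4 `CCCCN(c1nc2c(C(=O)O)cccc2o1)[C@H](C)c1ccc(-c2cc(F)ccc2-c2nc(=O)o[nH]2)cc1` is reached from compound 2 by a single change: fluoro in place of chloro on an aromatic carbon. Compound 4 thus carries the same fluoro substituent as compound 1 while keeping the butyl chain of compound 2, so it sits between the two measured neighbours in structure. For the measured compounds named here, no measured pair differs by this one exchange alone, so the size of the step cannot be read from the data directly.

A small shift toward a longer half-life is expected in this assay, of about a 1.4-fold higher number from compound 2 to compound 4 (0.15 log units; within the scatter), which stays within the scatter. Compound 4 is therefore estimated at 2.8 h, with a likely range from 1.4 h to 5.6 h.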

Compound 4, half-life: 2.2 h
Estimate against measurement, compound 4: 1.3-fold (0.10 log units) above; the measured number falls inside the stated range.
By their numbers in this assay, from the lowest: compounds 2, 4, 3 and 1 (each within the scatter of the next, the first and the last beyond it).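

In this assay, the exchange of chloro for fluoro now has a measured size (a 1.1-fold higher number from compound 2 to compound 4 (0.04 log units; within the scatter)), so on an aromatic carbon meta to a large group and para to a group of 6 heavy atoms, these two substituents cannot be told apart by half-life. The same compound also gives a second single-place comparison on the other side of the molecule (a 1.9-fold lower number from compound 1 to compound 4 (0.27 log units; within the scatter)), which shows that propyl in place of cyclopropyl on a saturated chain carbon bound to a nitrogen on an aromatic ring also stays inside the usual scatter, so neither change stands out on its own. Nothing available here accounts for what sets these half-lives.

On these data alone, whether a clearly different group on the same aromatic carbon, such as a nitrile or a methoxy group, would move the half-life beyond the scatter remains open. Also open, as far as these compounds go, is whether the fluoro and chloro groups would stay equally close with the cyclopropyl-bearing chain of compound 1 in place of the butyl chain.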